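This account rests on a few compounds, and the source may have more. Where it says the series, first, only, none or still open, it means among the compounds named here.

Working notes on the series. Compound 1 `CCCCCCCCCCCCCCCCCCNC(=O)[C@@H]1CSC(c2ccc(N(C)C)cc2)N1` gives 3000 nM in a functional assay on TSU-Pr1 cells (Homo sapiens) for antiproliferative activity, read by sulforhodamine B assay; a lower number here means a stronger inhibitor, a higher number a weaker inhibitor. Compound 2 `CCCCCCCCCCCCCCCCCCNC(=O)[C@@H]1CSC(c2ccc(O)cc2)N1`, which carries a hydroxy in place of the dimethylamino on the aromatic carbon, gives 3000 nM in this assay, and the step from compound 1 to compound 2 is no change at the digits printed from compound 1 to compound 2 (within the scatter). On the numbers shown, compound 2 therefore stands level with compound 1; neither can be called the more potent of the two.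

Compound 3 `CCCCCCCCCCCCCCCCCCNC(=O)[C@@H]1CSC(c2c(OC)cc(OC)cc2OC)N1` is not yet measured. The change from compound 2 is 2,4,6-trimethoxyphenyl in place of 4-hydroxyphenyl on a saturated ring carbon. Going by the values given here, the only measured step that bears on it is the one from compound 1 to compound 2, which altered the same aromatic ring at the same position and was within the scatter. That step exchanged one group for one group; the present change replaces the 4-hydroxyphenyl with a 2,4,6-trimethoxyphenyl, a larger substitution, so the precedent is only partial. Among the compounds with values here, no measured compound shows what such an exchange does in this assay. The expectation is therefore a step of no change at the digits printed from compound 2 to compound 3 (within the scatter), none beyond the scatter, with wide uncertainty. Compound 3 is estimated at 3000 nM in this assay, within a range of 800 nM to 12000 nM.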

Compound 3, half-maximal inhibitory concentration: 6100 nM
Estimate against measurement, compound 3: 2.0-fold (0.31 log units) below; measured number inside the range.
By their numbers in this assay, from the lowest: compounds 1 and 2 (each within the scatter of the next); then compound 3.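

At this saturated ring carbon, the result in this assay shows that the aryl group can move the number beyond the scatter, which the earlier pair of compounds did not show: 2,4,6-trimethoxyphenyl in place of 4-hydroxyphenyl gives a 2.0-fold higher number from compound 2 to compound 3 (0.31 log units; beyond the scatter) and, in place of 4-(dimethylamino)phenyl, gives a 2.0-fold higher number from compound 1 to compound 3 (0.31 log units; beyond the scatter) in the same direction. Both steps are modest, but they make compound 3 the weakest inhibitor of the three, so this larger exchange is not tolerated as fully as the exchange between the two single substituents was. Nothing measured connects this loss to any one feature of the exchange.

The compounds shown do not separate the effect of the added methoxy groups from that of losing the hydroxy or dimethylamino group, and a 4-methoxyphenyl or 2,6-dimethoxyphenyl group would bear directly on that question. Also open, on these data alone, is how a carboxylic acid on the aromatic ring, or a shorter chain in place of the long chain on the shared core, would read.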